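Swapping an Amino Chain for a Cyclopentyl Ether

The source may hold more compounds than are shown below. What is called first, only, known or untested is meant among the compounds shown, and "the series" means these compounds.

Of the compounds shown here, three sharing one amide framework have been measured in an assay on cells for antagonist activity at transient receptor potential cation channel subfamily V member 1 (Homo sapiens), read by FLIPR and calcium flux, with a stated time of 6 min; a lower number here means a stronger inhibitor, a higher number a weaker inhibitor. Compound 1 `CC(C)CCOc1nc(C(C)(C)C)ccc1CNC(=O)C(C)c1ccc(NS(C)(=O)=O)c(F)c1` gives 0.8 nM. Compound 2 `CCCCSc1nc(C(C)(C)C)ccc1CNC(=O)C(C)c1ccc(NS(C)(=O)=O)c(F)c1` gives 3.2 nM. Compound 3 `CCCCN(C)c1cc(C(C)(C)C)ccc1CNC(=O)C(C)c1ccc(NS(C)(=O)=O)c(F)c1` gives 1 nM, which places it second highest of the three numbers, within the scatter of compound 1 and beyond the scatter of compound 2.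

Compound 4 `CC(C(=O)NCc1ccc(C(C)(C)C)cc1OC1CCCC1)c1ccc(NS(C)(=O)=O)c(F)c1` is not yet measured. It differs from compound 3 in one place: cyclopentyloxy in place of butyl(methyl)amino on an aromatic carbon.

Among the compounds with values here, only one measured step exists, a 4.0-fold higher number from compound 1 to compound 2 (0.60 log units; beyond the scatter), and it concerns a different pair of groups on the shared core. It shows that exchanging the chain in this region can move the number by a modest amount, but it says nothing directly about a cyclopentyloxy group. With the three measured numbers all close together, the expectation for compound 4 is a step of about a 1.3-fold higher number from compound 3 to compound 4 (0.11 log units; within the scatter), that is, no change beyond the scatter. The estimated value for compound 4 in this assay is 1.3 nM, with a likely range from 0.4 nM to 4.5 nM.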

Compound 4, inhibition constant: 1.8 nM
Compound 4: the middle estimate sits 1.4-fold (0.14 log units) below what was measured; the measured number falls inside the stated range.
By their numbers in this assay, from the lowest: compounds 1, 3, 4 and 2 (each within the scatter of the next, the first and the last beyond it).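

In this assay the swap gives a 1.8-fold higher number from compound 3 to compound 4 (0.26 log units; within the scatter) on the same aromatic carbon, ortho to a large group and meta to a tert-butyl group. So this position accepts a cyclopentyloxy ring in place of the open butyl(methyl)amino chain, with the same count of heavy atoms and hydrogen-bond acceptors, and the result stays within the usual scatter; the earlier compounds held no step on this core. No supporting data bear on this result.

The swap changes the linking atom and closes a ring at once, so the two changes cannot be told apart here. A butoxy chain or a cyclopentylamino group at this position would separate them, and a much smaller methoxy group would test how far this tolerance extends.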